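Changing the Amide Aryl Group Once More

The compounds below may be only part of what the source reports. "The series", "measured", "known", "first", "only" and "open" are said of these compounds alone.

Compound 2 `CCOC(=O)c1sc(-c2cccc(NC(=O)c3ccc(F)c(Cl)c3)c2)nc1Nc1ccc(N2CCN(C)CC2)cc1` gives 20.7% in a functional assay on Raji cells (Homo sapiens) for antiproliferative activity, read by CCK-8 assay, with a stated time of 72 h, tested at 40 uM (a lower number here means less inhibition, a higher number more inhibition at the concentration tested (going by the name of the read-out)), the lower of the two numbers recorded so far. For the measured compounds named here, compound 1 `CCOC(=O)c1sc(-c2cccc(NC(=O)c3ccccc3)c2)nc1Nc1ccc(N2CCN(C)CC2)cc1` gives 42% in this assay, and the single measured step, a number 21.3 percentage points lower from compound 1 to compound 2 (beyond the scatter), lies beyond the scatter. Compound 3 `CCOC(=O)c1sc(-c2cccc(NC(=O)c3ccc(C(F)(F)F)cn3)c2)nc1Nc1ccc(N2CCN(C)CC2)cc1` differs from compound 2 by 5-(trifluoromethyl)pyridin-2-yl in place of 3-chloro-4-fluorophenyl on a carbonyl carbon. Going by the values given here, the step from compound 1 to compound 2 is the only one available and concerns the same carbonyl carbon, but it exchanges a different pair of groups, so it shows only that the group at this position can shift the inhibition by a modest amount, without pointing to what the new group will do. Compound 3 is therefore expected to sit close to compound 2, with a wide range, at an estimated 27% between 8% and 48%. That estimate corresponds to an expected step of a number 6.3 percentage points higher from compound 2 to compound 3 (within the scatter), within the scatter.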

Compound 3, a percentage reported as inhibition, at one concentration (the size of the read-out at that concentration, not a potency): 20.8%
The estimate for compound 3 lay 6.2 percentage points above the measured number, and the stated range covers the measured number.
By their numbers in this assay, from the lowest: compounds 2 and 3 (each within the scatter of the next); then compound 1.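

In this assay, replacing 3-chloro-4-fluorophenyl with 5-(trifluoromethyl)pyridin-2-yl on the carbonyl carbon gives a number 0.1 percentage points higher from compound 2 to compound 3 (within the scatter), so this exchange of two substituted aromatic rings leaves the two compounds indistinguishable. Measured against the unsubstituted phenyl, the new group gives a number 21.2 percentage points lower from compound 1 to compound 3 (beyond the scatter), so among the three compounds shown, both substituted groups stand apart from phenyl, although they share neither ring type nor substituents. No measurement available here bears on the reason for this.

The compounds shown leave open whether the ring nitrogen or the trifluoromethyl group counts for more on its own, as the two enter together in compound 3. An unsubstituted pyridin-2-yl group would separate them, while an amine on the phenyl ring would test a substituent of another kind at this position.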